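Chloro to methyl on the aromatic ring: cytotoxicity notes

The source may report more compounds than this note shows. Statements on the series, on what has been measured and on what is new or still open speak of the compounds shown alone.

Compound 1 `Cn1nnnc1SCC(=O)N/N=C/c1ccc(C(F)(F)F)cc1`: 6320000 nM
Compound 2 `Cn1nnnc1SCC(=O)N/N=C/c1cccc(Cl)c1`: 7500000 nM

In a functional assay on A549 cells (Homo sapiens) for cytotoxicity, read by XTT assay, with a stated time of 24 h (on this read-out lower numbers stand for stronger inhibition and higher numbers for weaker inhibition), compound 1 gives 6320000 nM and compound 2 gives 7500000 nM; the two numbers lie within the scatter of each other, so neither stands apart. Compound 3 `Cc1cccc(/C=N/NC(=O)CSc2nnnn2C)c1` is not yet measured. It differs from compound 2 by methyl in place of chloro on an aromatic carbon. Going by the values given here, no step between measured compounds is known, and nothing in the two numbers points in either direction, so no change beyond the scatter is expected. For compound 3 the estimate is 7000000 nM, range 3000000 nM to 16000000 nM, a step of a 1.1-fold lower number from compound 2 to compound 3 (0.03 log units; within the scatter).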

Compound 3, half-maximal inhibitory concentration: 2000000 nM
Compound 3: the middle estimate sits 3.5-fold (0.54 log units) above what was measured; measured number below the stated range.
By their numbers in this assay, from the lowest: compound 3; then compounds 1 and 2 (each within the scatter of the next).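

In this assay, going by these compounds alone, methyl in place of chloro on an aromatic carbon, meta to a large group, gives a 3.8-fold lower number from compound 2 to compound 3 (0.57 log units; beyond the scatter) and is the first step that can be read. This place therefore responds to an exchange of one heavy atom for another, with no change in ring, hydrogen-bond donors, hydrogen-bond acceptors or net charge. No measurement on hand accounts for this step.

Still open, going by these compounds, is how an amine or a carboxylic acid at this place would compare with methyl. On these data alone, whether the same exchange holds elsewhere on the ring also remains open.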